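The source may hold more compounds than are shown below. What is called first, only, known or untested is meant among the compounds shown, and "the series" means these compounds.

In a functional assay on HL-60 cells (Homo sapiens) for antiproliferative activity, read by XTT assay, with a stated time of 72 h (a lower number here means a stronger inhibitor, a higher number a weaker inhibitor), compound 1 `COc1ncnc2c1c(-c1ccoc1)cn2[C@@H]1O[C@H](CO)[C@@H](O)[C@H]1O` gives 150 nM, the lowest of the two plain numbers shown. Compound 2 `CN(C)c1ncnc2c1c(-c1ccoc1)cn2[C@@H]1O[C@H](CO)[C@@H](O)[C@H]1O` gives 1160 nM, a modest step of a 7.7-fold higher number from compound 1 to compound 2 (0.89 log units; beyond the scatter). Compound 3 `Cc1ncnc2c1c(-c1ccoc1)cn2[C@@H]1O[C@H](CO)[C@@H](O)[C@H]1O` gives only a limit of this assay, > 15000 nM, and so sits at the limit of > 15000 nM in this assay, at which 1 of the 3 values shown sits. The steps of an at least 100-fold higher number from compound 1 to compound 3 (2.00 log units; beyond the scatter) and an at least 12-fold higher number from compound 2 to compound 3 (1.11 log units; beyond the scatter) are large. All three measured steps swap the group on the same aromatic carbon of the shared core and leave the furan-3-yl untouched.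

Compound 4 `COc1ncnc2c1c(-c1ccccc1)cn2[C@@H]1O[C@H](CO)[C@@H](O)[C@H]1O` differs from compound 1 by phenyl in place of furan-3-yl on an aromatic carbon. No measured step swaps this group, so nothing shown speaks to it directly. The step of a 1.5-fold higher number from compound 1 to compound 4 (0.17 log units; within the scatter) is expected to stay within the scatter. Compound 4 is therefore estimated at 220 nM, between 60 nM and 800 nM.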

Compound 4, half-maximal inhibitory concentration: > 20000 nM
Compound 4: no number, only a limit (the forecaster's own chance of this, stated with the estimate: 5%); middle value at least 90-fold (1.95 log units) from the limit.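

Earlier steps changed only the group on the other aromatic carbon, while the furan-3-yl stayed in place. This position matters too: replacing furan-3-yl with phenyl gives an at least 130-fold higher number from compound 1 to compound 4 (2.12 log units; beyond the scatter). Compound 4 reaches only a limit in this assay: the limit of > 20000 nM in this assay, at which 1 of the 4 values shown sits.

The compounds shown cannot separate ring size from the loss of the ring oxygen, so it stays open whether thiophen-3-yl, pyridin-3-yl or furan-2-yl would keep the activity of compound 1. As far as these compounds go, whether phenyl has the same effect alongside the dimethylamino group of compound 2 also remains open.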